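The source may hold more compounds than are shown below. What is called first, only, known or untested is meant among the compounds shown, and "the series" means these compounds.

Measured compounds in a functional assay on DU-145 cells (Homo sapiens) for antiproliferative activity, read by MTT assay; on this read-out lower numbers stand for stronger inhibition and higher numbers for weaker inhibition:
- compound 1 `CN1CCN(c2nc(-n3ccc4ccccc43)c3ccccc3n2)CC1`: 20.8 ug/mL
- compound 2 `COc1cc(OC)c(-c2nc(N3CCN(C)CC3)nc3ccccc23)c(OC)c1`: 50 ug/mL
- compound 3 `COc1ccc(-c2nc(N3CCN(C)CC3)nc3ccccc23)c(OC)c1`: 50 ug/mL

Compound 1 gives the lowest number of the three, and both compound 2 and compound 3 lie beyond the scatter from it. Going by the values given here, the only step between measured compounds, no change at the digits printed from compound 2 to compound 3 (within the scatter), concerns hydrogen in place of methoxy on an aromatic carbon and leaves this assay unchanged.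

Compound 4 `c1ccc(N2CCN(c3nc(-n4ccc5ccccc54)c4ccccc4n3)CC2)nc1` differs from compound 1 by pyridin-2-yl in place of methyl on an amine nitrogen in a ring. Among the compounds with values here, no measured step touches the amine nitrogen in a ring, so nothing here tells how this assay answers such a change; the single step on record, on an aromatic carbon, was flat. Compound 4 is therefore expected to stay close to compound 1, with a step of a 1.2-fold lower number from compound 1 to compound 4 (0.06 log units; within the scatter), and its estimate in this assay is 18 ug/mL within 6 ug/mL to 55 ug/mL.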

Compound 4, half-maximal inhibitory concentration: 50 ug/mL
Compound 4: middle estimate off by 2.8-fold (0.44 log units), on the low side; measured number inside the range.
By their numbers in this assay, from the lowest: compound 1; then compounds 2, 3 and 4 (each within the scatter of the next).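

Going by these compounds alone, the amine nitrogen in a ring, which no earlier step touched, does respond in this assay: pyridin-2-yl in place of methyl gives a 2.4-fold higher number from compound 1 to compound 4 (0.38 log units; beyond the scatter), a modest loss of inhibition. At this position, the single methyl carbon therefore gives a lower number than the six-atom aromatic ring. No data on hand bear on the reason for this step.

One pair cannot show whether the ring nitrogen of pyridin-2-yl matters or the size of the group. Phenyl, ethyl or a longer chain on the same amine nitrogen remains open.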